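Removing the Chloro Group from a Hydrazone Analogue

The source may hold more compounds than are shown below. What is called first, only, known or untested is meant among the compounds shown, and "the series" means these compounds.

Measured compounds:
compound 1 `COc1ccc(OC)c(/C=C/c2nnc(Nc3ccc(Cl)cc3)o2)c1`: > 100000 nM
compound 2 `COc1ccc(OC)c(/C=C/C(=O)N/N=C/c2ccc(Cl)cc2)c1`: > 100000 nM

Compound 1 and compound 2 were tested in a functional assay on MDA-MB-468 cells (Homo sapiens) for antiproliferative activity, read by sulforhodamine B assay, with a stated time of 48 h; on this read-out higher numbers stand for lower toxicity in this test and lower numbers for higher toxicity in this test. For compound 1 the result is a limit of the assay, > 100000 nM. For compound 2 the result is likewise a limit of the assay, > 100000 nM. Within the data shown here, compound 2 thus stands at the limit of > 100000 nM in this assay, at which 2 of the 2 values shown sit, together with the only other measured compound. Compound 3 `COc1ccc(OC)c(/C=C/C(=O)N/N=C/c2ccccc2)c1` differs from compound 2 by hydrogen in place of chloro on an aromatic carbon. Among the measured compounds shown here, no step between measured compounds is available, and no step beyond the scatter is expected in this assay. The expected step of a number no higher from compound 2 to compound 3 (the limit leaves the size open) is estimated to stay within the scatter. Compound 3 is expected to give about 100000 nM, between 30000 nM and 300000 nM, most likely again as a limit.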

Compound 3, concentration lethal to 50% of the cells: 61600 nM
Estimate against measurement, compound 3: 1.6-fold (0.21 log units) above, within the range that was stated.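

In this assay the change from 4-chlorophenyl to phenyl gives an at least 1.6-fold lower number from compound 2 to compound 3 (0.21 log units; that floor lies within the scatter). Among these compounds, compound 3 gives 61600 nM, the only value shown that is a number and not a limit, so for the first time this series gives a measured value with hydrogen at this position. The step remains only a floor, as compound 2 is a limit of the assay: the limit of > 100000 nM in this assay, at which 2 of the 3 values shown sit.

From the compounds shown here alone, how far the true step runs past that floor stays open. So does what an amine or a carboxylic acid on this aromatic carbon would give.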